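Shorter Chain with an Ether Oxygen on the Core

The source may report more compounds than this note shows. Statements on the series, on what has been measured and on what is new or still open speak of the compounds shown alone.

Measured so far:
- compound 1, `CCCCCn1nc2ccccc2c1OC`: 3880 nM
- compound 2, `CCCCCCCCn1nc2ccccc2c1OC`: > 10000 nM
- compound 3, `CCCCCCCCn1nc2ccccc2c1OCC`: > 10000 nM

All three share one core and differ only in the chain on the aromatic nitrogen or in the group on the ring oxygen. In an assay on isolated protein (urine) for inhibition of Myeloperoxidase (Homo sapiens), read by spectrophotometry (on this read-out lower numbers stand for stronger inhibition and higher numbers for weaker inhibition), compound 1 gives 3880 nM. For compound 2 the value > 10000 nM is a limit of this assay, not a number. For compound 3 the value > 10000 nM is likewise a limit. Compound 2 therefore stands at the limit of > 10000 nM in this assay, at which 2 of the 3 values shown sit, with no exact figure.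

The measured steps show an at least 2.5-fold higher number from compound 1 to compound 2 (0.41 log units; beyond the scatter) and a step that the two limits leave unreadable from compound 2 to compound 3.

Compound 4, `COCCn1nc2ccccc2c1OC`, differs from compound 2 by methoxy in place of hexyl on a saturated chain carbon, two bonds along the chain from an aromatic nitrogen. Among the compounds with values here, the only step that bears on it is the one from compound 1 to compound 2, where a longer chain on the aromatic nitrogen went with a higher number; compound 4 carries a chain shorter than either. Because an at least 2.5-fold higher number from compound 1 to compound 2 (0.41 log units; beyond the scatter) points that way, the expected step of an at least 2.0-fold lower number from compound 2 to compound 4 (0.30 log units; that floor lies within the scatter) is a lower number for compound 4, though a limit cannot be ruled out. Compound 4 is thus estimated at 5000 nM, within a range from 1500 nM to 20000 nM.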

Compound 4, half-maximal inhibitory concentration: 1080 nM
Estimate against measurement, compound 4: 4.6-fold (0.67 log units) above; the whole stated range lies above it.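

At this place, on a saturated chain carbon, two bonds along the chain from an aromatic nitrogen, methoxy in place of propyl gives a 3.6-fold lower number from compound 1 to compound 4 (0.56 log units; beyond the scatter) in this assay. This shows that the chain can carry an ether oxygen and still read lower than the pentyl chain of compound 1, so a lower number is not confined to an all-carbon chain. Methoxy in place of hexyl gives an at least 9.2-fold lower number from compound 2 to compound 4 (0.96 log units; beyond the scatter), but that size is only a floor and not an exact step, as compound 2 stands at a limit of the assay: the limit of > 10000 nM in this assay, at which 2 of the 4 values shown sit.

Among the compounds shown, the shorter chain and the ether oxygen arrive together in compound 4, so it stays open which of the two goes with the lower number. As far as these compounds go, a propyl chain with no oxygen on the aromatic nitrogen would bear on that question, and how an amine or a carboxylic acid would read in place of methoxy at this position also remains open.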